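Cyano to methoxy on the aryl urea of compound 2

This account rests on a few compounds, and the source may have more. Where it says the series, first, only, none or still open, it means among the compounds named here.

Measured compounds:
- compound 1, `CNc1nccc(N2CC[C@H](NC(=O)Nc3ccc(CN(C)C)c(C(F)(F)F)c3)C2)n1`: 40.1 nM
- compound 2, `CNc1nccc(N2CC[C@H](NC(=O)Nc3cccc(C#N)c3)C2)n1`: 3480 nM
- compound 3, `O=C(Nc1ccc(Cl)c(C(F)(F)F)c1)N[C@H]1CCN(c2ccncn2)C1`: 60.3 nM

Three ureas were tested in an assay on a protein complex for displacement of a labelled ligand from CDK8/Cyclin C (Homo sapiens), read by TR-FRET, with a stated time of 1 h; on this read-out lower numbers stand for stronger inhibition and higher numbers for weaker inhibition. Compound 1 gives 40.1 nM and compound 3 gives 60.3 nM, both of them carrying a trifluoromethyl on the aryl ring. Compound 2, with a cyano group instead, gives 3480 nM, the highest number of the three; its gap to compound 3 and to compound 1 lies beyond the scatter in each case.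

Compound 4, `CNc1nccc(N2CC[C@H](NC(=O)Nc3cccc(OC)c3)C2)n1`, has not yet been measured. It differs from compound 2 in one place: methoxy in place of cyano on an aromatic carbon. Going by the values given here, no measured pair in this set shows the effect of such a change, so the expectation rests on the small size of the group that leaves and the group that enters. The step from compound 2 to compound 4 in this assay is expected to be modest, a 1.2-fold lower number from compound 2 to compound 4 (0.06 log units; within the scatter), with no direction firmly indicated. Compound 4 is therefore estimated at 3000 nM, within a range of 1000 nM to 9000 nM.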

Compound 4, half-maximal inhibitory concentration in the CDK8/Cyclin C assay: 3620 nM
Compound 4: the middle estimate sits 1.2-fold (0.08 log units) below what was measured, within the range that was stated.
By their numbers in the CDK8/Cyclin C assay, from the lowest: compounds 1 and 3 (each within the scatter of the next); then compounds 2 and 4 (each within the scatter of the next).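

Going by these compounds alone, in the CDK8/Cyclin C assay the exchange of 3-cyanophenyl for 3-methoxyphenyl gives a 1.0-fold higher number from compound 2 to compound 4 (0.02 log units; within the scatter) and is the first step in the set that differs in one place, so this position does not separate cyano from methoxy on this read-out. In a physicochemical assay for solubility, measured as kinetic solubility (a higher number here means a more soluble compound, a lower number a less soluble compound), compound 2 gives 95700 nM and compound 4 gives 116000 nM and these two lie within the scatter of each other, so the two groups do not separate there either. No measurement at hand says why the two groups read alike.

Still open, going by these compounds, is whether any group at this position would shift the number in the CDK8/Cyclin C assay at all, for instance an amine, a carboxylic acid or a longer chain. Also open, on these data alone, is what a trifluoromethyl in place of the cyano would do on the core of compound 2, as compound 1 and compound 3 differ from it in more than one place.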